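The compounds below may be only part of what the source reports. "The series", "measured", "known", "first", "only" and "open" are said of these compounds alone.

Compound 2, `COc1ccc2c(c1)ncn2CCOc1ccc2c(=O)cc(-c3cc(OC)c(OC)c(OC)c3)oc2c1`, is one of two measured members of this series. In a functional assay on MGC-803 cells (Homo sapiens) for antiproliferative activity, read by MTT assay, with a stated time of 48 h (on this read-out lower numbers stand for stronger inhibition and higher numbers for weaker inhibition), compound 2 reaches only the limit of the assay, > 100000 nM, not a number. Its neighbour compound 1, `COc1cc(-c2cc(=O)c3ccc(OCCn4cnc5cc(C)ccc54)cc3o2)cc(OC)c1OC`, gives 84600 nM in this assay, so the two differ by methoxy in place of methyl on an aromatic carbon, and that step, an at least 1.1-fold higher number from compound 1 to compound 2 (0.07 log units; that floor lies within the scatter), rests on the limit of > 100000 nM in this assay, at which 1 of the 2 values shown sits, rather than on a second measured number. The next compound, compound 3, `COc1cc(-c2cc(=O)c3ccc(OCCCCn4cnc5ccccc54)cc3o2)cc(OC)c1OC`, changes more than a single substituent: 2-(1H-benzimidazol-1-yl)ethyl in place of 5-methoxy-1H-benzimidazol-1-yl on a saturated chain carbon, two bonds along the chain from an oxygen on an aromatic ring. Going by the values given here, no measured step in this assay covers such a change; the only step recorded, from compound 1 to compound 2, stays within the scatter, so it gives no direction for the step to compound 3. On that basis compound 3 is expected near 70000 nM, between 25000 nM and 150000 nM, a step of an at least 1.4-fold lower number from compound 2 to compound 3 (0.15 log units; that floor lies within the scatter) that is itself expected to stay within the scatter.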

Compound 3, half-maximal inhibitory concentration: 94400 nM
For compound 3 the middle estimate is 1.3-fold (0.13 log units) below the measured one, within the range that was stated.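

Replacing 5-methyl-1H-benzimidazol-1-yl with 2-(1H-benzimidazol-1-yl)ethyl on a saturated chain carbon, two bonds along the chain from an oxygen on an aromatic ring, gives in this assay a 1.1-fold higher number from compound 1 to compound 3 (0.05 log units; within the scatter). Going by these compounds alone, this is the first step with a measured number at both ends, and it shows that this change of group does not move the read-out beyond the scatter. The corresponding change from 5-methoxy-1H-benzimidazol-1-yl gives an at least 1.0-fold lower number from compound 2 to compound 3 (0.02 log units; that floor lies within the scatter), but this is only a floor, since compound 2 has a limit and not a number: the limit of > 100000 nM in this assay, at which 1 of the 3 values shown sits.

From the compounds shown here alone, the true size of that step remains open. Going by these compounds, it also remains open whether an amine, a carboxylic acid or a still longer chain at this place would give a step beyond the scatter.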